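Terminal group and chain length on the ether side

This account rests on a few compounds, and the source may have more. Where it says the series, first, only, none or still open, it means among the compounds named here.

Compound 1 `O=C(O)CCCCCCCCCCCOc1ccc2c(=O)c(-c3ccc(O)cc3)coc2c1`: in an assay (Cricetulus griseus) for inhibition of aldehyde dehydrogenase, mitochondrial (Homo sapiens) (on this read-out lower numbers stand for stronger inhibition and higher numbers for weaker inhibition), compound 1 gives 130 nM.
Compound 2 `O=c1c(-c2ccc(O)cc2)coc2cc(OCCCCCCCCCCCCO)ccc12`: in this assay compound 2 gives 1700 nM.
Compound 3 `NCCCCOc1ccc2c(=O)c(-c3ccc(O)cc3)coc2c1`: in this assay compound 3 gives 250 nM.

Compound 3 holds the second highest of the three numbers. Its nearest neighbour is compound 1, with a 1.9-fold higher number from compound 1 to compound 3 (0.28 log units; within the scatter), a gap within the scatter, so no order between those two is claimed. Its furthest is compound 2, with a 6.8-fold lower number from compound 2 to compound 3 (0.83 log units; beyond the scatter).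

Compound 4 `O=c1c(-c2ccc(O)cc2)coc2cc(OCCCCCCO)ccc12` is not yet measured. It differs from compound 3 by 2-hydroxyethyl in place of amino on a saturated chain carbon, four bonds along the chain from an oxygen on an aromatic ring. Among the compounds with values here, two measured steps bear on this change. The step of a 6.8-fold lower number from compound 2 to compound 3 (0.83 log units; beyond the scatter) runs the other way: amino in place of a chain ending in a hydroxyl lowered the number beyond the scatter, though that chain was 8-hydroxyoctyl, longer than the 2-hydroxyethyl entering here. The step of a 13-fold higher number from compound 1 to compound 2 (1.12 log units; beyond the scatter) shows that, on a long chain, a hydroxymethyl end gives a much higher number than a carboxy end. Both steps have a terminal hydroxyl on the weaker side; what a shorter chain alone does cannot be read from three compounds. A higher number than compound 3 is therefore expected in this assay, a step of a 3.2-fold higher number from compound 3 to compound 4 (0.51 log units; beyond the scatter), modest rather than large.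

Compound 4 is estimated at 800 nM, with a range from 300 nM to 2500 nM.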

Compound 4, half-maximal inhibitory concentration: 120 nM
The estimate for compound 4 lay 6.7-fold (0.82 log units) above the measured number, outside the stated range (below it).
By their numbers in this assay, from the lowest: compounds 4, 1 and 3 (each within the scatter of the next, the first and the last beyond it); then compound 2.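

In this assay, a terminal hydroxyl does not by itself go with a high number: with the hydroxyl end kept and the chain shortened by 6-hydroxyhexyl, the step is a 14-fold lower number from compound 2 to compound 4 (1.15 log units; beyond the scatter), so chain length counts at this position, at least between these two compounds. The shorter hydroxyl-ended chain also stands on the low side of the amino-ended chain, with a 2.1-fold lower number from compound 3 to compound 4 (0.32 log units; beyond the scatter), although this step changes the end group and the chain length together and credits neither alone. Against the long carboxy-ended chain, a 1.1-fold lower number from compound 1 to compound 4 (0.03 log units; within the scatter) lies within the scatter, so the loss seen with the long hydroxyl-ended chain is not seen with the shorter one, and no order between those two is claimed.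

Nothing given here explains why the shorter chain carries the lower number. End group and chain length remain tied together in these compounds, and it stays open how a carboxylic acid or an amine on the chain of compound 4, or a hydroxyl on the shorter chain of compound 3, would read, and whether the number changes gradually with length.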